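This account rests on a few compounds, and the source may have more. Where it says the series, first, only, none or still open, it means among the compounds named here.

Of the compounds shown here, three built on one shared core have been tested in a functional assay on aorta (strain Wistar) for inhibition, with Thoracic aorta (Rattus norvegicus) as the target; on this read-out higher numbers stand for weaker inhibition and lower numbers for stronger inhibition. Compound 1 `COc1nc(-c2cc3ccccc3o2)cc(-c2ccc3ccccc3c2)c1C#N` gives 320000 nM in this assay. Compound 2 `CCOc1nc(-c2cc3ccccc3o2)cc(-c2ccc3ccccc3c2)c1C#N` gives 423000 nM. Compound 3 `COc1nc(-c2cc3ccccc3o2)cc(-c2ccc(F)cc2)c1C#N` gives 321000 nM. Among the measured compounds shown here, the only pair that differs in a single place is compounds 1 and 2, and that step, a 1.3-fold higher number from compound 1 to compound 2 (0.12 log units; within the scatter), is too small to count as a real change. Compound 2 therefore sits level with compounds 1 and 3, all three separated by amounts that lie within the scatter of repeated measurements.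

Compound 4 `CCOc1nc(-c2cc3ccccc3o2)cc(-c2ccc(C)cc2)c1C#N` has not yet been measured. It differs from compound 2 by 4-methylphenyl in place of naphthalen-2-yl on an aromatic carbon. For the measured compounds named here, no measured step covers this exact exchange. The closest hint comes from compounds 1 and 3, which differ at the same place on the core: compound 1 gives 320000 nM and compound 3 gives 321000 nM, two figures that are practically identical. On that basis the exchange is expected to leave this assay essentially unchanged, with a step of a 1.1-fold lower number from compound 2 to compound 4 (0.02 log units; within the scatter) that stays within the scatter. Compound 4 is therefore estimated at 400000 nM in this assay, with a likely range from 200000 nM to 800000 nM.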

Compound 4, half-maximal inhibitory concentration: 290000 nM
Compound 4: the middle estimate sits 1.4-fold (0.14 log units) above what was measured, within the range that was stated.
By their numbers in this assay, from the lowest: compounds 4, 1, 3 and 2 (each within the scatter of the next).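

In this assay, trading naphthalen-2-yl, which has 2 six-membered aromatic rings of carbon only, for 4-methylphenyl, which has one, gives a 1.5-fold lower number from compound 2 to compound 4 (0.16 log units; within the scatter), so this direct exchange on the aromatic carbon opposite the ring nitrogen produces no readable change. Until now, the only hint at this position came from a related exchange with a methoxy group on the core, where compound 1 gives 320000 nM and compound 3 gives 321000 nM; the new step extends that picture to a core carrying an ethoxy group and to a different para-free comparison of ring size. Nothing measured here offers an explanation for the flat result.

All the groups shown at this position are aromatic rings of carbon only, so it remains open whether a phenyl ring carrying an amine or a carboxylic acid would move the number beyond the scatter. The nitrile and the 1-benzofuran-2-yl group are the same in every compound, which leaves open whether exchanging either of them, for example the nitrile for an amide, would matter more than anything changed so far.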